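The compounds below may be only part of what the source reports. "The series", "measured", "known", "first", "only" and "open" are said of these compounds alone.

Working notes on the series. In a functional assay on HeLa cells (Homo sapiens) for inhibition, read by sulforhodamine B assay (a higher number here means a weaker inhibitor, a lower number a stronger inhibitor), compound 3 `COc1ccc(NC2=CC(=O)c3nc4n(c3C2=O)[C@H]2OC[C@@H](O)[C@H]2OC4)cc1` gives 4780 nM; of the two numbers in hand it sits at the upper end, with compound 1 `Cc1ccc(NC2=CC(=O)c3nc4n(c3C2=O)[C@H]2OC[C@@H](O)[C@H]2OC4)cc1C` nearest at 2690 nM, a gap within the scatter. Compound 2 `O=C1C=C(NC2CCCC2)C(=O)c2c1nc1n2[C@H]2OC[C@@H](O)[C@H]2OC1` yields only a limit, > 16000 nM; this is the limit of > 16000 nM in this assay, at which 1 of the 3 values shown sits. Compound 4 `COc1ccccc1NC1=CC(=O)c2nc3n(c2C1=O)[C@H]1OC[C@@H](O)[C@H]1OC3` differs from compound 3 by 2-methoxyphenyl in place of 4-methoxyphenyl on an amine nitrogen. The aryl-for-aryl comparison available is a 1.8-fold higher number from compound 1 to compound 3 (0.25 log units; within the scatter), whereas an at least 5.9-fold higher number from compound 1 to compound 2 (0.77 log units; beyond the scatter) and an at least 3.3-fold lower number from compound 2 to compound 3 (0.52 log units; beyond the scatter) concern cyclopentyl and bear less directly. For compound 4 the expected step is therefore a 1.2-fold higher number from compound 3 to compound 4 (0.06 log units; within the scatter), nothing clearly beyond the scatter in this assay. Compound 4 is estimated at 5500 nM, with a range from 2000 nM to 16000 nM.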

Compound 4, half-maximal inhibitory concentration: 2950 nM
Beside the measured number, compound 4's estimate is 1.9-fold (0.27 log units) above it; measured number inside the range.
By their numbers in this assay, from the lowest: compounds 1, 4 and 3 (each within the scatter of the next). At a limit, above all of these: compound 2.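

In this assay, the 2-methoxyphenyl group in place of the 4-methoxyphenyl group on the amine nitrogen stays within the scatter (a 1.6-fold lower number from compound 3 to compound 4 (0.21 log units; within the scatter)), so moving the methoxy group shows no clear effect. The same holds against 3,4-dimethylphenyl (a 1.1-fold higher number from compound 1 to compound 4 (0.04 log units; within the scatter)), leaving compounds 1, 3 and 4 indistinguishable, whereas 2-methoxyphenyl in place of cyclopentyl goes beyond the scatter (an at least 5.4-fold lower number from compound 2 to compound 4 (0.73 log units; beyond the scatter)). Compound 2 gives only a limit: the limit of > 16000 nM in this assay, at which 1 of the 4 values shown sits.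

As far as these compounds go, whether a benzyl group or a pyridine ring on the amine nitrogen would track with the aryl compounds or with cyclopentyl remains open.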